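Swapping a Sulfonyl Cap for an Acetyl Cap

The source may report more compounds than this note shows. Statements on the series, on what has been measured and on what is new or still open speak of the compounds shown alone.

Of the compounds shown here, three sharing one core have been tested in a functional assay on MCF7 cells (Homo sapiens) for cytotoxicity, read by MTT assay, with a stated time of 48 h; on this read-out lower numbers stand for stronger inhibition and higher numbers for weaker inhibition. Compound 1 `COc1cccc(-c2cnc3[nH]cc(-c4ccncc4)c3c2)c1` gives 11700 nM, compound 3 `Nc1ccc(-c2cnc3[nH]cc(-c4ccncc4)c3c2)cc1` gives 7700 nM, and compound 2 `Nc1cc(NS(=O)(=O)c2ccccc2)cc(-c2cnc3[nH]cc(-c4ccncc4)c3c2)c1` gives 8800 nM. On these numbers compound 2 stands second highest, yet its gaps to compound 3 and to compound 1 both fall within the usual scatter, so the three cannot be told apart. Compound 4 `CC(=O)Nc1cc(N)cc(-c2cnc3[nH]cc(-c4ccncc4)c3c2)c1` has not been measured; it differs from compound 2 in one place: acetyl in place of phenylsulfonyl on a nitrogen on an aromatic ring. Among the compounds with values here, no measured pair shows the effect of this change. The step expected is therefore a 1.0-fold higher number from compound 2 to compound 4 (0.01 log units; within the scatter), meaning nothing beyond the usual scatter in either direction. For compound 4 the expected value in this assay is 9000 nM, with a range from 4000 nM to 20000 nM.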

Compound 4, half-maximal inhibitory concentration: > 30000 nM
Compound 4 was reported as a limit (the forecaster's own chance of this, stated with the estimate: 5%); middle value at least 3.3-fold (0.52 log units) away from the limit.
By their numbers in this assay, from the lowest: compounds 3, 2 and 1 (each within the scatter of the next). At a limit, above all of these: compound 4.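

At this nitrogen on an aromatic ring, acetyl in place of phenylsulfonyl gives an at least 3.4-fold higher number from compound 2 to compound 4 (0.53 log units; beyond the scatter), so the cap on this nitrogen can change the number in this assay. The earlier compounds shown here offered no pair differing in one place, and so could not show this. Compound 4 is recorded only as a limit, not a number: the limit of > 30000 nM in this assay, at which 1 of the 4 values shown sits.

Which part of phenylsulfonyl matters remains open, the sulfonyl or its aromatic ring. A methylsulfonyl or benzoyl cap on the same nitrogen would begin to separate the two.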